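A Smaller Fused Ring at the End of the Chain

The source may hold more compounds than are shown below. What is called first, only, known or untested is meant among the compounds shown, and "the series" means these compounds.

Among the measured compounds shown here, compound 1 `c1ccc2c(c1)CC(CCCN1CCN(c3cccc4c3OCCO4)CC1)C2` is the only one of the three compounds with an actual number in a functional assay on the whole organism for agonist activity, with Rattus norvegicus as the target; on this read-out higher numbers stand for an effect only at larger amounts of compound and lower numbers for an effect already at smaller amounts: compound 1 gives 40 mg/kg. For compound 2 `C1=C(CCN2CCN(c3cccc4c3OCCO4)CC2)c2ccccc2CC1` this assay reports only a limit, > 40 mg/kg. For compound 3 `c1ccc2c(c1)CC2CN1CCN(c2cccc3c2OCCCO3)CC1` this assay likewise reports only a limit, > 10 mg/kg. Compound 4 `c1ccc2c(c1)CC2CCCCN1CCN(c2cccc3c2OCCO3)CC1` has not yet been measured. It differs from compound 1 in one place: a group of 9 heavy atoms (9 carbon; one four-membered non-aromatic ring of carbon only, one six-membered aromatic ring of carbon only) in place of a group of 9 heavy atoms (9 carbon; one five-membered non-aromatic ring of carbon only, one six-membered aromatic ring of carbon only), on a saturated chain carbon, three bonds along the chain from an amine nitrogen in a ring. For the measured compounds named here, no step between two measured compounds is at hand, so there is nothing measured to size this change against; a small step is expected, none beyond the usual scatter, in either direction. Compound 4 is therefore expected at 40 mg/kg, with a range from 10 mg/kg to 160 mg/kg. The expected change is no change at the digits printed from compound 1 to compound 4 (within the scatter).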

Compound 4, minimum effective dose: > 10 mg/kg
Compound 4 was reported as a limit; the forecaster's own chance of this, stated with the estimate: 30%; the middle value lies beyond the limit too.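

Among the compounds shown here, compound 4 is reported only as a limit, > 10 mg/kg, so no step from compound 1 to compound 4 can be read. From the compounds shown here alone, whether the four-membered ring shifts the dose needed in this assay relative to the five-membered ring of compound 1 stays open.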